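Chloro to Methyl on a Second Core: Expected Potency

This account rests on a few compounds, and the source may have more. Where it says the series, first, only, none or still open, it means among the compounds named here.

Of the compounds shown here, three have been measured for their ability to slow the growth of a human skin cancer cell line. Compound 1 `COc1cc2ncnc(Nc3cccc(Cl)c3)c2cc1OCCCCC(=O)Nc1ccc(S(N)(=O)=O)cc1` gives 30400 nM in a functional assay on A-431 cells (Homo sapiens) for antiproliferative activity, read by MTT assay, with a stated time of 72 h; on this read-out higher numbers stand for weaker inhibition and lower numbers for stronger inhibition. Compound 2 `COc1cc2ncnc(Nc3cccc(C)c3)c2cc1OCCCCC(=O)Nc1ccc(S(N)(=O)=O)cc1` differs from it in a single place, (methyl in place of chloro on an aromatic carbon), and in this assay compound 2 gives 7460 nM; the change produced a 4.1-fold lower number from compound 1 to compound 2 (0.61 log units; beyond the scatter). Compound 3 `NS(=O)(=O)c1ccc(NC(=S)Nc2ccc3ncnc(Nc4cccc(Cl)c4)c3c2)cc1` carries a different core, and in this assay compound 3 gives 15000 nM. The difference between the core of compound 1 and the core of compound 3 is not broken down here.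

Compound 4 `Cc1cccc(Nc2ncnc3ccc(NC(=S)Nc4ccc(S(N)(=O)=O)cc4)cc23)c1` has not yet been measured. It stands to compound 3 as compound 2 stands to compound 1: methyl in place of chloro on an aromatic carbon. The surroundings of the exchanged group are described in the same words in both pairs. This is the same change, made on another core.

The expected step from compound 3 to compound 4 in this assay is a 3.3-fold lower number from compound 3 to compound 4 (0.52 log units; beyond the scatter), resting on the measured step of a 4.1-fold lower number from compound 1 to compound 2 (0.61 log units; beyond the scatter), and tempered, since a change made once need not repeat in size. On this basis compound 4 is estimated to give 4500 nM, with a plausible range from 1500 nM to 14000 nM.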

Compound 4, half-maximal inhibitory concentration: 23800 nM
Compound 4: middle estimate off by 5.3-fold (0.72 log units), on the low side; the measured number lies above the stated range.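

On the second core, exchanging chloro for methyl gives a 1.6-fold higher number from compound 3 to compound 4 (0.20 log units; within the scatter) in this assay, so compound 3 and compound 4 cannot be told apart on this read-out. The clear step seen on the first core therefore did not carry over in size to the second: the same change on two cores in this assay, a 4.1-fold lower number (0.61 log units; beyond the scatter) from compound 1 to compound 2 and a 1.6-fold higher number (0.20 log units; within the scatter) from compound 3 to compound 4, 6.5-fold (0.81 log units) apart, beyond the scatter of two such steps This shows that, in this series, a step measured on one core can be a poor guide to the same exchange on another, but two pairs cannot show why the cores respond differently or predict what a further core would do.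

The compounds shown leave open which part of the difference between the two cores matters, since those cores are compared here only as wholes. They also leave open whether a bromo or an ethyl group in place of the chloro would follow the same course on both cores.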